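Estimating Compound 4 After an Aryl Swap

The source may hold more compounds than are shown below. What is called first, only, known or untested is meant among the compounds shown, and "the series" means these compounds.

Compound 1, `COc1ccc(S(=O)(=O)N(Cc2cccc(I)c2)[C@H](C)C(=O)O)cc1`, 280 nM
Compound 2, `COc1ccc(S(=O)(=O)N(Cc2ccc(OC)c(C)c2C)[C@H](C)C(=O)O)cc1`, 200 nM
Compound 3, `COc1ccc(S(=O)(=O)N(Cc2cccc(C)c2[N+](=O)[O-])[C@H](C)C(=O)O)cc1`, 380 nM

Of the compounds shown here, three sharing one core have been measured in an assay on isolated protein for inhibition of bone morphogenetic protein 1 (Homo sapiens); on this read-out higher numbers stand for weaker inhibition and lower numbers for stronger inhibition. In this assay compound 1 gives 280 nM, compound 2 gives 200 nM and compound 3 gives 380 nM. The number for compound 1 lies close to both others: the gap to compound 3 is within the usual scatter, and so is the gap to compound 2. On these numbers the three compounds cannot be told apart.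

The next compound, compound 4, `COc1ccc(S(=O)(=O)N(Cc2ccc(Br)cc2F)[C@H](C)C(=O)O)cc1`, has not yet been measured. It differs from compound 1 in a single place: 4-bromo-2-fluorophenyl in place of 3-iodophenyl on a saturated chain carbon bound to a sulfonamide nitrogen. Both the group that leaves and the group that enters are single aromatic rings carrying halogen, with no hydrogen-bond donors or acceptors and no charge, and the core is untouched. Among the compounds with values here, no comparable pair of measured compounds shows what such a swap does here, so the expectation rests on the narrow spread of the three known numbers.

The step of a 1.1-fold higher number from compound 1 to compound 4 (0.03 log units; within the scatter) is expected to be small, in no clear direction, and not beyond the scatter. Compound 4 is expected to give about 300 nM in this assay, with a range from 120 nM to 750 nM.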

Compound 4, half-maximal inhibitory concentration: 490 nM
Compound 4: middle estimate off by 1.6-fold (0.21 log units), on the low side; measured number inside the range.
By their numbers in this assay, from the lowest: compounds 2, 1, 3 and 4 (each within the scatter of the next, the first and the last beyond it).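

Within the data shown here, the swap of 3-iodophenyl for 4-bromo-2-fluorophenyl on a saturated chain carbon bound to a sulfonamide nitrogen gives, in this assay, a 1.8-fold higher number from compound 1 to compound 4 (0.24 log units; within the scatter), and this is the first step at this position in which a single place changes. It shows that this position tolerates one halogen-bearing aromatic ring being replaced by another, going from 7 heavy atoms to 8 and changing which halogens the ring carries, without a step beyond the usual scatter of the measurement. No measurement is available that explains the size of this step or separates the part played by the iodine from that of the bromine or the fluorine.

All the compounds shown carry a substituted aromatic ring at this position, so it remains open whether an unsubstituted phenyl ring, a saturated cyclohexyl ring or a simple methyl group would give a number close to these. On these data alone, it also remains open whether a ring carrying an amine or a carboxylic acid, which would add groups unlike the halogens, methyl, methoxy and nitro groups seen so far, would stay within the same narrow band.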